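Nitro in Place of Trifluoromethoxy on a Shared Urea Core

A few compounds are considered here, and "the series" means these few. Any claim that something is new, unique, unknown or untested is made for them only; others in the source may bear on it.

Measured so far:
- compound 1 `Cc1cc(NC(=O)Nc2ccccc2OC(F)(F)F)c2ccccc2n1`: > 25000 nM
- compound 2 `Cc1cc(NC(=O)Nc2cccc(F)c2)c2ccccc2n1`: > 25000 nM

Both were tested in an ADME assay on HepG2 cells (Homo sapiens) for cytotoxicity, with a stated time of 72 h; on this read-out lower numbers stand for an effect already at smaller amounts and higher numbers for an effect only at larger amounts of compound. For compound 1 the result, > 25000 nM, is a limit of the assay rather than a number. The same holds for compound 2, whose result > 25000 nM is likewise a limit. Among the measured compounds shown here, compound 1 therefore stands at the limit of > 25000 nM in this assay, at which 2 of the 2 values shown sit; no numerical value separates it from compound 2, and no step between measured compounds can be drawn from these two results.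

The compound now to be measured is compound 3 `Cc1cc(NC(=O)Nc2ccccc2[N+](=O)[O-])c2ccccc2n1`. It differs from compound 1 by nitro in place of trifluoromethoxy on an aromatic carbon. Since compound 1 only marks a limit, there is no measured step to lean on; on the numbers shown, the expectation for this assay is no step beyond the scatter, with compound 3 expected to sit at the same limit as compound 1. The estimated step of a number no higher from compound 1 to compound 3 (the limit leaves the size open) is thus expected to be flat. On that basis compound 3 is estimated at 25000 nM, within a range from 8000 nM to 60000 nM.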

Compound 3, half-maximal effective concentration: > 25000 nM
Compound 3: no number, only a limit (the forecaster's own chance of this, stated with the estimate: 80%); the middle value lies on the limit itself.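

Compound 3 gives > 25000 nM as a limit of the assay and not a number. Compound 1 also gives only a limit, so no step can be read between compound 1 and compound 3: the limit of > 25000 nM in this assay, at which 3 of the 3 values shown sit.

The compounds shown leave open what concentration, if any, would bring out an effect, and whether nitro and trifluoromethoxy differ.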